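Swapping a methyl-bearing phenyl for a fluorophenyl amide

The compounds below may be only part of what the source reports. "The series", "measured", "known", "first", "only" and "open" are said of these compounds alone.

Three measured compounds share one core and differ only in the aryl group attached to the amide carbonyl. Compound 1 `CN(C)c1nc(N[C@H]2CC[C@@H](NC(=O)c3ccc(F)c(F)c3F)CC2)nc2ccccc12` gives 38 nM in an assay on HEK293 cells for inhibition of melanin-concentrating hormone receptor 1 (Homo sapiens), read by radioligand binding; on this read-out higher numbers stand for weaker inhibition and lower numbers for stronger inhibition. Compound 2 `CN(C)c1nc(N[C@H]2CC[C@@H](NC(=O)c3ccccc3F)CC2)nc2ccccc12` gives 170 nM in this assay. Compound 3 `Cc1cccc(C(=O)N[C@H]2CC[C@@H](Nc3nc(N(C)C)c4ccccc4n3)CC2)c1` gives 4.6 nM in this assay, the lowest of the three numbers, and its steps to the others are both beyond the scatter.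

Compound 4 `CN(C)c1nc(N[C@H]2CC[C@@H](NC(=O)c3ccc(F)cc3)CC2)nc2ccccc12` has not yet been measured. It differs from compound 3 in one place: 4-fluorophenyl in place of 3-methylphenyl on a carbonyl carbon.

Within the data shown here, two measured steps bear on this change. Going from a fluorinated phenyl to 3-methylphenyl gave an 8.3-fold lower number from compound 1 to compound 3 (0.92 log units; beyond the scatter) and a 37-fold lower number from compound 2 to compound 3 (1.57 log units; beyond the scatter). Compound 4 reverses that direction, replacing 3-methylphenyl with a fluorinated phenyl, though with a different fluorine pattern from either measured one. A higher number for compound 4 than for compound 3 is therefore expected, roughly an 8.7-fold higher number from compound 3 to compound 4 (0.94 log units; beyond the scatter). Compound 4 is estimated at 40 nM, within a range of 10 nM to 160 nM.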

Compound 4, half-maximal inhibitory concentration: 9.4 nM
Estimate against measurement, compound 4: 4.3-fold (0.63 log units) above; the measured number lies below the stated range.
By their numbers in this assay, from the lowest: compound 3; then compound 4; then compound 1; then compound 2.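

In this assay, a fluorinated phenyl on the carbonyl carbon need not cost much: 4-fluorophenyl in place of 3-methylphenyl gives a 2.0-fold higher number from compound 3 to compound 4 (0.31 log units; beyond the scatter), a far smaller step than either earlier fluorinated phenyl showed against compound 3. The fluorine pattern therefore matters, not just the presence of fluorine, as 4-fluorophenyl in place of 2-fluorophenyl gives an 18-fold lower number from compound 2 to compound 4 (1.26 log units; beyond the scatter), and 4-fluorophenyl in place of 2,3,4-trifluorophenyl gives a 4.0-fold lower number from compound 1 to compound 4 (0.61 log units; beyond the scatter). Nothing available here accounts for these differences.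

Compound 3 and compound 4 differ in both the kind of group and where it sits on the phenyl ring, so their step cannot separate the two. A pair such as 3-fluorophenyl and 4-methylphenyl on the same carbonyl carbon would pull those two changes apart.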